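Putting a sulfone back in place of the cyano group

The compounds below may be only part of what the source reports. "The series", "measured", "known", "first", "only" and "open" are said of these compounds alone.

In a physicochemical assay for solubility, read by HPLC, using the shake flask method, in phosphate buffer, with a stated time of 2 h, at pH 6.5 (on this read-out higher numbers stand for higher solubility and lower numbers for lower solubility), compound 2 (`N#Cc1ccc(-c2cnc(N)c(-c3ccc(N)nc3)n2)cc1`) reads < 5000 nM which is a limit and not a number. Compound 1 (`Nc1ccc(-c2nc(-c3ccc(S(=O)(=O)C4CC4)cc3)cnc2N)cn1`) gives 13000 nM as a measured number in this assay on the same scale. Among the compounds with values here, the one measured step that bears on what follows is an at least 2.6-fold lower number from compound 1 to compound 2 (0.41 log units; beyond the scatter) and it lies beyond the scatter, with cyano in place of cyclopropylsulfonyl on an aromatic carbon. Compound 3 (`CS(=O)(=O)c1ccc(-c2cnc(N)c(-c3ccc(N)nc3)n2)cc1`) runs the other way: methylsulfonyl in place of cyano on an aromatic carbon sets methylsulfonyl in place of cyano on an aromatic carbon, para to a large group. On the strength of an at least 2.6-fold lower number from compound 1 to compound 2 (0.41 log units; beyond the scatter) alone, a rise of similar modest size is expected in this assay although methylsulfonyl is not cyclopropylsulfonyl. The estimate means an at least 2.4-fold higher number from compound 2 to compound 3 (0.38 log units; beyond the scatter) as an expected step. For compound 3 the estimated value is 12000 nM with an expected range from 5000 nM to 30000 nM in this assay for now.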

Compound 3, solubility: 149000 nM
Estimate against measurement, compound 3: 12-fold (1.09 log units) below, outside the stated range (above it).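

Methylsulfonyl in place of cyano on an aromatic carbon, para to a large group, gives an at least 29-fold higher number from compound 2 to compound 3 (1.47 log units; beyond the scatter), a large step where the earlier exchange with cyclopropylsulfonyl had shown an at least 2.6-fold lower number from compound 1 to compound 2 (0.41 log units; beyond the scatter). Compound 2 stands as a limit and not a number, so the size of each step from or to it is only a bound: the limit of < 5000 nM in this assay, at which 1 of the 3 values shown sits. Between the two sulfones, methyl in place of cyclopropyl on a sulfonyl sulfur gives an 11-fold higher number from compound 1 to compound 3 (1.06 log units; beyond the scatter), so the read-out at this position turns on what the sulfonyl group carries and not on the sulfonyl group alone.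

The compounds shown leave open whether a longer chain such as ethyl, or an amine on the sulfonyl sulfur, would read like methyl or like cyclopropyl. They also do not tell why the two sulfones differ, and the high value rests on compound 3 alone.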